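The source may hold more compounds than are shown below. What is called first, only, known or untested is meant among the compounds shown, and "the series" means these compounds.

Working notes on a three-compound set sharing one core, all read in a functional assay on MCF7 cells (Homo sapiens) for inhibition, read by MTT assay, with a stated time of 48 h; on this read-out lower numbers stand for stronger inhibition and higher numbers for weaker inhibition. Compound 1 `COc1cc2cc(C(=O)NCCCc3ccc(F)cc3)c(=O)oc2cc1OCCCOc1no[n+]([O-])c1S(=O)(=O)c1ccccc1` gives 600 nM. Compound 2 `COc1ccc(NC(=O)c2cc3cc(OC)c(OCCCOc4no[n+]([O-])c4S(=O)(=O)c4ccccc4)cc3oc2=O)cc1` gives 410 nM in this assay, and the exchange of the amide substituent gave a 1.5-fold lower number from compound 1 to compound 2 (0.17 log units; within the scatter). Compound 3 `COc1cc2cc(N)c(=O)oc2cc1OCCCOc1no[n+]([O-])c1S(=O)(=O)c1ccccc1` gives 2020 nM in this assay, the highest of the three numbers; the loss of the amide for amino gave a 4.9-fold higher number from compound 2 to compound 3 (0.69 log units; beyond the scatter), so compound 3 sits well beyond the scatter above both compound 1 and compound 2.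

Compound 4 `COc1cc2cc(C(=O)NCc3ccccc3)c(=O)oc2cc1OCCCOc1no[n+]([O-])c1S(=O)(=O)c1ccccc1` is not yet measured. Its change from compound 3 is benzylcarbamoyl in place of amino on an aromatic carbon. Among the measured compounds shown here, two measured steps bear on it. The step from compound 2 to compound 3 is the reverse direction of this change, and the step from compound 1 to compound 2 shows that two different carbamoyl substituents on this nitrogen fall within the scatter of each other. A lower number is therefore expected for compound 4, of a size close to the reverse of the step that gave a 4.9-fold higher number from compound 2 to compound 3 (0.69 log units; beyond the scatter), landing near the numbers of compound 1 and compound 2. The expected step is a 3.7-fold lower number from compound 3 to compound 4 (0.56 log units; beyond the scatter). Compound 4 is thus estimated at 550 nM, with a range from 250 nM to 1200 nM.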

Compound 4, half-maximal inhibitory concentration: 740 nM
Compound 4: middle estimate off by 1.3-fold (0.13 log units), on the low side; measured number inside the range.
By their numbers in this assay, from the lowest: compounds 2, 1 and 4 (each within the scatter of the next); then compound 3.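

In this assay, a third carbamoyl substituent on this aromatic carbon, two atoms from the ring oxygen, again stands apart from the amino group of compound 3 with a 2.7-fold lower number from compound 3 to compound 4 (0.44 log units; beyond the scatter) as its step, so the gap between amino and carbamoyl now rests on a second pair and not on one amide alone. The benzyl amide does not separate from the other two amides, with a 1.8-fold higher number from compound 2 to compound 4 (0.26 log units; within the scatter) and a 1.2-fold higher number from compound 1 to compound 4 (0.09 log units; within the scatter) as its steps, so benzyl, 4-methoxyphenyl and 3-(4-fluorophenyl)propyl on the amide-type nitrogen cannot be told apart on this read-out. No supporting measurement is at hand to explain the gap between the amino group and the amides.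

Going by these compounds, what a carboxylic acid, an ester or a simple methyl amide would give on this aromatic carbon stays open, and so does whether the aromatic ring in the amide substituent is needed at all. The rest of the molecule is the same in all four compounds, so a longer chain to the sulfonyl-bearing ring system or another group on the phenyl sulfone remains unaddressed.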